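The source may report more compounds than this note shows. Statements on the series, on what has been measured and on what is new or still open speak of the compounds shown alone.

Compound 1 `C=C1CC[C@H]2[C@@](C)(CC[C@@H](OC(C)=O)[C@@]2(C)C(=O)OCc2ccccn2)[C@@H]1CCC1=CCOC1=O`: 55500 nM
Compound 2 `C=C1CC[C@H]2[C@@](C)(CC[C@@H](O)[C@@]2(C)C(=O)OCc2ccccn2)[C@@H]1CCC1=CCOC1=O`: 79800 nM
Compound 3 `C=C1CC[C@H]2[C@@](C)(CC[C@@H](OC(C)=O)[C@@]2(C)C(=O)OC)[C@@H]1/C=C/C1=CCOC1=O`: 32300 nM

These three compounds were tested in a functional assay on NIH3T3 cells (Mus musculus) for inhibition, read by MTT assay, with a stated time of 72 h; a higher number here means a weaker inhibitor, a lower number a stronger inhibitor. Compound 1 and compound 2 share a core and differ in one spot: hydrogen in place of acetyl on an oxygen on a saturated carbon. That change gave a 1.4-fold higher number from compound 1 to compound 2 (0.16 log units; within the scatter), so the two values cannot be told apart. Compound 3 rests on a different core; the difference between the two cores is not broken down here. Compound 3 shows the lowest of the three numbers, but its gap to compound 1 lies within the scatter, while its gap to compound 2 lies beyond it.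

Compound 4 `C=C1CC[C@H]2[C@@](C)(CC[C@@H](O)[C@@]2(C)C(=O)OC)[C@@H]1/C=C/C1=CCOC1=O` has not yet been measured in this assay. It differs from compound 3 by hydrogen in place of acetyl on an oxygen on a saturated carbon, the same change as between compound 1 and compound 2, at a place described in the same words. Because that earlier step was a 1.4-fold higher number from compound 1 to compound 2 (0.16 log units; within the scatter), the step from compound 3 to compound 4 is expected to be small as well, a 1.4-fold higher number from compound 3 to compound 4 (0.14 log units; within the scatter). Compound 4 is therefore estimated at 45000 nM, with a likely range from 20000 nM to 100000 nM.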

Compound 4, half-maximal inhibitory concentration: 111000 nM
Compound 4: middle estimate off by 2.5-fold (0.39 log units), on the low side; measured number outside the range, above it.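

Going from acetoxy to hydroxy gave a 3.4-fold higher number from compound 3 to compound 4 (0.54 log units; beyond the scatter) in this assay, so on this core the change produces a real difference, unlike on the other core. Even so, the change moves the number in the same direction on both cores, and the two steps cannot be told apart: the same change on two cores in this assay, a 1.4-fold higher number (0.16 log units; within the scatter) from compound 1 to compound 2 and a 3.4-fold higher number (0.54 log units; beyond the scatter) from compound 3 to compound 4, 2.4-fold (0.38 log units) apart, within the scatter of two such steps. The data therefore fit a single effect carried from one core to the other, but two pairs cannot prove that the step transfers unchanged, and they do not explain why it looks larger here.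

The compounds shown leave open what other groups on an oxygen on this saturated carbon would do, such as a benzoyl ester or a methyl ether. They also leave open which of the differences between the two cores, if any, matters for the size of this step.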